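The source may hold more compounds than are shown below. What is called first, only, known or untested is meant among the compounds shown, and "the series" means these compounds.

Three compounds have been measured in an ADME assay on HepG2 cells (Homo sapiens), read by MTT assay, with a stated time of 72 h, in the presence of a further agent that is not named here; on this read-out higher numbers stand for weaker inhibition and lower numbers for stronger inhibition:

Compound 1 `O=C(NC1CCCCC1)Oc1ccccc1C(=O)Nc1ccccc1` gives 51500 nM.
Compound 2 `O=C(Nc1ccccc1)Oc1ccc(Cl)cc1C(=O)Nc1ccc(Cl)cc1` gives 900 nM.
Compound 3 `O=C(Nc1ccccc1)Oc1ccccc1C(=O)Nc1ccccc1` gives 26800 nM.

Compound 2 is the strongest inhibitor of the three in this assay: its number lies below those of compound 3 and compound 1 by margins beyond the usual scatter. Compound 2 and compound 3 share the same overall layout but differ in more than one place, so the difference between the two cores is not broken down here.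

Compound 1 and compound 3 differ in a single place: cyclohexyl in place of phenyl on an amide-type nitrogen. That change produced a 1.9-fold higher number from compound 3 to compound 1 (0.28 log units; within the scatter), a step within the scatter of repeated measurements, so the two compounds cannot be told apart in this read-out.

Compound 4 `O=C(NC1CCCCC1)Oc1ccc(Cl)cc1C(=O)Nc1ccc(Cl)cc1` has not yet been measured. It is related to compound 2 by the same change: cyclohexyl in place of phenyl on an amide-type nitrogen. The place reads the same in both cases, an amide-type nitrogen whose other neighbour is a carbonyl carbon, so this is the same change, made on the core of compound 2 rather than the core of compound 3.

The expectation rests on that single earlier step. Because the earlier change gave a 1.9-fold higher number from compound 3 to compound 1 (0.28 log units; within the scatter), a small shift is expected again. The step to compound 4 is expected to be a 1.7-fold higher number from compound 2 to compound 4 (0.22 log units; within the scatter). Compound 4 is therefore expected to give 1500 nM in this assay, most likely between 600 nM and 4000 nM.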

Compound 4, half-maximal inhibitory concentration: 33600 nM
The estimate for compound 4 lay 22-fold (1.35 log units) below the measured number, outside the stated range (above it).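

In this assay, putting cyclohexyl in place of phenyl on the amide-type nitrogen of the chlorine-bearing core gave a 37-fold higher number from compound 2 to compound 4 (1.57 log units; beyond the scatter), a large loss of inhibition. This shows that the size of the effect of this change does not carry over unchanged from one core to the other, so a step measured on one core is a poor guide to the step on the other: the same change on two cores in this assay, a 1.9-fold higher number (0.28 log units; within the scatter) from compound 3 to compound 1 and a 37-fold higher number (1.57 log units; beyond the scatter) from compound 2 to compound 4, 19-fold (1.29 log units) apart, beyond the scatter of two such steps. Among the compounds shown here, it does not show why the two steps differ, since the two cores differ in more than one place, and with only one pair of compounds on each core it cannot establish a general rule for this series.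

From the compounds shown here alone, it remains open which chlorine in the core of compound 2 makes phenyl on that nitrogen so much better than cyclohexyl, and whether bromine or a methyl group in place of chlorine would do the same. Also open, going by these compounds, is how other groups on the amide-type nitrogen, such as benzyl or a straight hexyl chain, would fare on each core, and so whether the large step is specific to cyclohexyl or extends to other groups that replace phenyl.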